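The source may report more compounds than this note shows. Statements on the series, on what has been measured and on what is new or still open speak of the compounds shown alone.

In a functional assay on MDA-MB-231 cells (Homo sapiens) for cytotoxicity, read by MTT assay, with a stated time of 48 h (a lower number here means a stronger inhibitor, a higher number a weaker inhibitor), compound 1 `Fc1ccc(C(CCCCOCc2ccc(Oc3ccc(Cl)cc3)cc2)c2ccc(F)cc2)cc1` reaches only the limit of the assay, > 20000 nM, and so gives no number; this is the point described by the limit of > 20000 nM in this assay, at which 1 of the 3 values shown sits. The other two compounds keep the shared core but replace the ether linkage with a urea that carries a nitrophenyl on an amide-type nitrogen. Compound 2 `O=C(NCCCCC(c1ccc(F)cc1)c1ccc(F)cc1)Nc1ccc([N+](=O)[O-])cc1`, with a 4-nitrophenyl, gives 6470 nM in this assay. Compound 3 `O=C(NCCCCC(c1ccc(F)cc1)c1ccc(F)cc1)Nc1cccc([N+](=O)[O-])c1`, with a 3-nitrophenyl, gives 3790 nM in this assay. Among the compounds with values here, the single measured step between them, a 1.7-fold lower number from compound 2 to compound 3 (0.23 log units; within the scatter), stays within the scatter, so compound 3 and compound 2 stand together, and the third value is a limit rather than a number.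

Compound 4 `Cc1cc(Cl)ccc1NC(=O)NCCCCC(c1ccc(F)cc1)c1ccc(F)cc1` differs from compound 3 in one place: 4-chloro-2-methylphenyl in place of 3-nitrophenyl on an amide-type nitrogen. Within the data shown here, no measured step bears on this change, since the only step available swaps the position of a nitro group and says nothing about trading a nitro group for a chlorine and a methyl. With nothing pointing in either direction, the step from compound 3 is expected to be none beyond the scatter, a 1.1-fold higher number from compound 3 to compound 4 (0.02 log units; within the scatter), though the uncertainty is wide. Compound 4 is therefore estimated at 4000 nM, with a range from 1200 nM to 15000 nM.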

Compound 4, half-maximal inhibitory concentration: > 20000 nM
Compound 4 gave a limit, no number (the forecaster's own chance of this, stated with the estimate: 15%); at least 5.0-fold (0.69 log units) between middle value and limit.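

Moving the nitro group had told little, but replacing the whole 3-nitrophenyl or 4-nitrophenyl on the amide-type nitrogen does matter in this assay: the change to 4-chloro-2-methylphenyl gives an at least 5.2-fold higher number from compound 3 to compound 4 (0.72 log units; beyond the scatter), and the same change from the other nitro compound gives an at least 3.0-fold higher number from compound 2 to compound 4 (0.49 log units; beyond the scatter). Both steps lie beyond the scatter, so among these three ureas the group on this nitrogen can decide whether a measured number is reached at all, with the two nitrophenyl compounds giving numbers and the 4-chloro-2-methylphenyl compound not. Compound 4 gives a limit and not a number, which places it alongside compound 1: the limit of > 20000 nM in this assay, at which 2 of the 4 values shown sit.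

The chlorine, the methyl and the loss of the nitro group all arrive in one change, so the compounds shown cannot say which of them accounts for the step, and a phenyl carrying only the chlorine or only the methyl would begin to separate them. From the compounds shown here alone, it also stays open whether the nitro group itself is needed, or whether a nitrile or an amine at that place on the ring would serve as well.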